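Butoxy for benzyl on an aminoindazole urea

The source may report more compounds than this note shows. Statements on the series, on what has been measured and on what is new or still open speak of the compounds shown alone.

Measured compounds:
Compound 1 `O=C(Nc1ccccc1OC(F)(F)F)Nc1n[nH]c2ccccc12` gives 22500 nM in a functional assay on M14 cells (Homo sapiens) for inhibition, read by sulforhodamine B assay, with a stated time of 48 h; on this read-out higher numbers stand for weaker inhibition of growth and lower numbers for stronger inhibition of growth.
Compound 2 `O=C(Nc1ccc(Cc2ccccc2)cc1)Nc1nn(C(=O)Nc2ccc(Cc3ccccc3)cc2)c2ccccc12` reaches only the limit > 100000 nM in this assay.
Compound 3 `Nc1nn(C(=O)Nc2ccc(Cc3ccccc3)cc2)c2ccccc12` gives 772 nM in this assay.

Among the two numbers that are not limits, compound 3 stands lowest, and compound 1 sits at a higher number by a gap beyond the scatter. For compound 2 the value is a limit of the assay rather than a number (the limit of > 100000 nM in this assay, at which 1 of the 3 values shown sits).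

Compound 4 `CCCCOc1ccc(NC(=O)n2nc(N)c3ccccc32)cc1` has not been measured. It differs from compound 3 by butoxy in place of benzyl on an aromatic carbon. Going by the values given here, no pair of measured compounds differing in a single place is available, so no measured step guides this change. The expected size of the step from compound 3 to compound 4 in this assay is small and slightly upward, at most near the edge of the scatter a 1.9-fold higher number from compound 3 to compound 4 (0.29 log units; within the scatter). For compound 4 the estimated value is 1500 nM, expected to fall between 400 nM and 6000 nM.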

Compound 4, concentration for 50% growth inhibition: 18600 nM
The estimate for compound 4 lay 12-fold (1.09 log units) below the measured number; the measured number lies above the stated range.
By their numbers in this assay, from the lowest: compound 3; then compounds 4 and 1 (each within the scatter of the next). At a limit, above all of these: compound 2.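

In this assay, going by these compounds alone, exchanging benzyl for butoxy on the aromatic carbon para to a large group gives a 24-fold higher number from compound 3 to compound 4 (1.38 log units; beyond the scatter), the first single-place comparison. It shows that this position does not accept every large group equally: with the rest of the molecule unchanged, the butoxy chain cannot stand in for benzyl without a loss of growth inhibition. Nothing measured here accounts for the size of this step.

The change removes a ring and brings in an oxygen at the same time, so the compounds shown do not tell which of the two matters. Going by these compounds, a phenoxy group, which keeps the ring with the oxygen, or a pentyl chain, which has neither ring nor oxygen, would separate the two, and how either behaves at this position remains open.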